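A few compounds are considered here, and "the series" means these few. Any claim that something is new, unique, unknown or untested is made for them only; others in the source may bear on it.

Measured so far in an assay on isolated protein for inhibition of 5-hydroxytryptamine receptor 4 (Homo sapiens); on this read-out lower numbers stand for stronger inhibition and higher numbers for weaker inhibition:
compound 1 `CCN1CCN(S(=O)(=O)CCCN2CCC(CNC(=O)c3cccc4c3OCCO4)CC2)CC1` gives 0.0501 nM;
compound 2 `CC1(C)CCN(S(=O)(=O)CCCN2CCC(CNC(=O)c3cccc4c3OCCO4)CC2)CC1` gives 0.126 nM;
compound 3 `O=C(NCC1CCN(CCCS(=O)(=O)N2CCN(Cc3cccnc3)CC2)CC1)c1cccc2c1OCCO2` gives 0.159 nM.

Compound 1 has the lowest number of the three, so on this read-out it is the strongest inhibitor shown. Its nearest neighbour is compound 2: a 2.5-fold higher number from compound 1 to compound 2 (0.40 log units; beyond the scatter). Compound 3 lies furthest from it: a 3.2-fold higher number from compound 1 to compound 3 (0.50 log units; beyond the scatter).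

Compound 4 `O=C(NCC1CCN(CCCS(=O)(=O)N2CCN(C3CCCC3)CC2)CC1)c1cccc2c1OCCO2` has not yet been measured. It differs from compound 1 in one place: cyclopentyl in place of ethyl on an amine nitrogen in a ring. Within the data shown here, two measured steps bear on this change, both altering the same end of the shared core. In the step to compound 2 the whole 4-ethylpiperazin-1-yl group was exchanged for 4,4-dimethylpiperidin-1-yl, and in the step to compound 3 a pyridin-3-yl replaced the methyl on an amine nitrogen in a ring. Each raised the number by a modest amount beyond the scatter, and neither lowered it. Going from ethyl to the larger cyclopentyl on the ring nitrogen is a change of the same kind, so for compound 4 a modest rise in this assay is expected rather than no change: a 2.2-fold higher number from compound 1 to compound 4 (0.34 log units; beyond the scatter). Compound 4 is therefore estimated at 0.11 nM, with a likely range from 0.04 nM to 0.32 nM.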

Compound 4, inhibition constant: 0.0159 nM
For compound 4 the middle estimate is 6.9-fold (0.84 log units) above the measured one, and the stated range ends above it.
By their numbers in this assay, from the lowest: compound 4; then compound 1; then compounds 2 and 3 (each within the scatter of the next).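

In this assay, the amine nitrogen in the ring accepts a larger all-carbon group with a gain rather than a loss, since cyclopentyl in place of ethyl gives a 3.2-fold lower number from compound 1 to compound 4 (0.50 log units; beyond the scatter), the first change shown here to lower the number. The same nitrogen carrying (pyridin-3-yl)methyl instead of cyclopentyl gives a 10-fold lower number from compound 3 to compound 4 (1.00 log units; beyond the scatter), and the exchange of 4,4-dimethylpiperidin-1-yl for 4-cyclopentylpiperazin-1-yl gives a 7.9-fold lower number from compound 2 to compound 4 (0.90 log units; beyond the scatter), which makes compound 4 the strongest inhibitor of the four; compound 3 shows that a large group on this nitrogen does not lower the number in every case. Nothing available here explains why cyclopentyl does better than ethyl at this position.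

The compounds shown leave open whether the gain depends on a ring at all, as an isopropyl group on the same nitrogen would test, and whether a cyclobutyl or cyclohexyl ring would lower the number further or raise it. They also leave open whether a cyclopentyl ring carrying a hydroxyl group or an amine would keep the gain.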